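A few compounds are considered here, and "the series" means these few. Any claim that something is new, unique, unknown or untested is made for them only; others in the source may bear on it.

Series of three measured compounds and one awaiting measurement. Compound 1 `ClCCCSc1nnc(COc2ccc(Cl)cc2Cl)o1` carries a 3-chloropropyl chain on the core, and compound 2 `CCCSc1nnc(COc2ccc(Cl)cc2Cl)o1` is its propyl counterpart. In a functional assay on BHK-21 cells (Mesocricetus auratus) for cytotoxicity, with a stated time of 5 days (a lower number here means that less compound is tolerated, a higher number that more compound is tolerated), compound 1 gives only a limit, > 50000 nM. In this assay compound 2 gives 13800 nM. The change hydrogen in place of chloro on a saturated chain carbon, three bonds along the chain from a sulfur therefore yields an at least 3.6-fold lower number from compound 1 to compound 2 (0.55 log units; beyond the scatter); the size of this step is bounded on one side only, because the limit of > 50000 nM in this assay, at which 2 of the 3 values shown sit, holds the starting point.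

Compound 3 `O=[N+]([O-])c1cccc(OCc2nnc(SCCCCl)o2)c1` differs from compound 1 in the aryl part; the difference between the two cores is not broken down here. In this assay compound 3 gives only a limit, > 50000 nM. Compound 4 `CCCSc1nnc(COc2cccc([N+](=O)[O-])c2)o1` is related to compound 3 by the same kind of change as before, (hydrogen in place of chloro on a saturated chain carbon, three bonds along the chain from a sulfur), at the same place. Among the compounds with values here, compound 2 at 13800 nM is the only firm number for the propyl chain. On that basis the step is expected at an at least 2.2-fold lower number from compound 3 to compound 4 (0.35 log units; beyond the scatter), of a size comparable to the earlier one. Compound 4 is estimated at 22000 nM, between 7000 nM and 50000 nM, with a real chance that only a limit is returned.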

Compound 4, half-maximal cytotoxic concentration: > 50000 nM
Compound 4 was reported as a limit (the forecaster's own chance of this, stated with the estimate: 40%); middle value at least 2.2-fold (0.35 log units) from the limit.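

No step can be read from compound 3 to compound 4, because both compounds are reported only as limits at the same value: the limit of > 50000 nM in this assay, at which 3 of the 4 values shown sit.

The compounds shown leave open whether 3-chloropropyl to propyl changes the number with the aryl part of compound 3 and compound 4 as it does with the aryl part of compound 1 and compound 2.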